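The compounds below may be only part of what the source reports. "The series", "measured", "known", "first", "only" and "open" are said of these compounds alone.

Two compounds carry the same core and the same amide on it, but differ in the ring that sits beyond the core and in the group on its carbonyl. Compound 1 `Cc1ccc(C(=O)Nc2cn3ncnc3c(O[C@H]3CCN(C(=O)CC(C(F)(F)F)C(F)(F)F)[C@@H](C)C3)c2C)cn1` is one of them. In an ADME assay on the whole organism (Mus musculus) for metabolic stability, using cassette dosing, at a dose of 2 umol/kg by the oral route (a lower number here means that the compound disappears faster, a higher number that the compound lasts longer), compound 1 gives 3.6 h. Compound 2 `Cc1ccc(C(=O)Nc2cn3ncnc3c(CN3CCN(C(=O)C4CCCC4)[C@@H](C)C3)c2C)cn1` is the other; in this assay compound 2 gives 1.2 h, the lower of the two values, and compound 1 stands a long way above it, a gap that lies beyond the usual scatter.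

Compound 3 `Cc1ccc(C(=O)Nc2cn3ncnc3c(CN3CCN(C(=O)CC(C(F)(F)F)C(F)(F)F)[C@@H](C)C3)c2C)cn1` has not been measured. It keeps the ring of compound 2 and changes only the group on the carbonyl carbon, whose other neighbour is an amide-type nitrogen in a ring: 3,3,3-trifluoro-2-(trifluoromethyl)propyl in place of cyclopentyl on a carbonyl carbon. For the measured compounds named here, that acyl group is the one compound 1 carries, yet the ring holding it differs, so no step directly covers this change. A modest rise is expected, of about a 1.8-fold higher number from compound 2 to compound 3 (0.26 log units; within the scatter). For compound 3 the expected half-life in this assay is 2.2 h, with a range from 1 h to 4.5 h.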

Compound 3, half-life: 1.1 h
For compound 3 the middle estimate is 2.0-fold (0.30 log units) above the measured one; measured number inside the range.
By their numbers in this assay, from the lowest: compounds 3 and 2 (each within the scatter of the next); then compound 1.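

In this assay, putting 3,3,3-trifluoro-2-(trifluoromethyl)propyl in place of cyclopentyl on a carbonyl carbon gives a 1.1-fold lower number from compound 2 to compound 3 (0.04 log units; within the scatter), so on this ring the half-life does not respond to swapping a ring of carbon only for an open group carrying fluorine. Compound 1, at 3.6 h, carries the same acyl group on a different ring, and this acyl group alone does not bring that number to the ring of compound 2. Nothing available here explains why the two groups give such close numbers.

Still open, going by these compounds, is whether a quite different group on this carbonyl, such as a phenyl ring, a longer chain or an amine, would shift the half-life. Also open, on these data alone, is how cyclopentyl would behave on the ring of compound 1.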